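From tetrazole to carbamoyl on the chain

The compounds below may be only part of what the source reports. "The series", "measured", "known", "first", "only" and "open" are said of these compounds alone.

Measured so far in a physicochemical assay for lipophilicity, using the shake flask method; a lower number here means a more polar compound, a higher number a more lipophilic compound:
compound 1 `C[C@H](Oc1ccc2ncc(CCC(=O)O)c(C3CC3)c2c1)c1c(Cl)ccc(F)c1Cl` gives 4.1
compound 2 `C[C@H](Oc1ccc2ncc(/C=C/c3nn[nH]n3)c(C3CC3)c2c1)c1c(Cl)ccc(F)c1Cl` gives 3.7

Among the measured compounds shown here, of these two compounds, compound 2 stands lowest, with compound 1 as its only and therefore nearest neighbour. Compound 3 `C[C@H](Oc1ccc2ncc(/C=C/C(N)=O)c(C3CC3)c2c1)c1c(Cl)ccc(F)c1Cl` has carbamoyl in place of 2H-tetrazol-5-yl on a double-bonded chain carbon bound to a double-bonded chain carbon. For the measured compounds named here, only one measured step bears on this change, and only indirectly. That step, a number 0.40 log units lower from compound 1 to compound 2 (beyond the scatter), is modest but beyond the scatter, and it also involves the 2H-tetrazol-5-yl group. Going by the values given here, no measured step exchanges this group for carbamoyl, so its size serves only as a rough guide and the direction remains a judgement. A modest rise is expected (a number 0.60 log units higher from compound 2 to compound 3 (beyond the scatter)). The estimated value for compound 3 is 4.3 (range 3.7 to 4.9).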

Compound 3, distribution coefficient: > 5.5
Compound 3: only a limit was reported (the forecaster's own chance of this, stated with the estimate: 5%); middle value at least 1.20 log units away from the limit.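

In this assay, carbamoyl in place of 2H-tetrazol-5-yl on the chain gives a number at least 1.80 log units higher from compound 2 to compound 3 (beyond the scatter), a large step where the only earlier one was modest. The end of this chain can therefore move the reading much further than a number 0.40 log units lower from compound 1 to compound 2 (beyond the scatter) suggested, and in the opposite direction, as the other large step shows: a number at least 1.40 log units higher from compound 1 to compound 3 (beyond the scatter). Compound 3 gives only a limit of the assay, not a number: the limit of > 5.5 in this assay, at which 1 of the 3 values shown sits.

From the compounds shown here alone, how far compound 3 lies past that limit remains open, as does how much of its step from compound 1 belongs to the double bond and how much to the carbamoyl, since that step changes both together. Also open, going by these compounds, is where a nitrile or a primary amine would fall on the same ethenyl chain.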